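The source may hold more compounds than are shown below. What is called first, only, known or untested is meant among the compounds shown, and "the series" means these compounds.

Among the measured compounds shown here, in a functional assay on BJAB cells (Homo sapiens) for antiproliferative activity, with a stated time of 4 days (on this read-out higher numbers stand for an effect only at larger amounts of compound and lower numbers for an effect already at smaller amounts), compound 2 `COc1cc(C#N)cc(-c2c(C)nn(-c3nc(-c4ccc(Cl)c(Cl)c4)c(SC(C)C)s3)c2C(=O)O)c1` gives 5200 nM, the lowest of the two numbers so far; compound 1 `COc1ccccc1-c1c(C)nn(-c2nc(-c3ccc(Cl)c(Cl)c3)c(SC(C)C)s2)c1C(=O)O` gives 14700 nM, and the one measured step, a 2.8-fold lower number from compound 1 to compound 2 (0.45 log units; beyond the scatter), came with the change to a ring bearing a nitrile. Compound 3 `CCOc1ncccc1-c1c(C)nn(-c2nc(-c3ccc(Cl)c(Cl)c3)c(SC(C)C)s2)c1C(=O)O` differs from compound 2 by 2-ethoxypyridin-3-yl in place of 3-cyano-5-methoxyphenyl on an aromatic carbon. For the measured compounds named here, no measured step covers this exact change; the single step shows that the group on that aromatic carbon moves the number only modestly, and dropping the nitrile may carry the number back toward that of compound 1. Compound 3 is therefore expected at 10000 nM (range 4000 nM to 30000 nM), an expected step of a 1.9-fold higher number from compound 2 to compound 3 (0.28 log units; within the scatter).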

Compound 3, half-maximal effective concentration: 11000 nM
Estimate against measurement, compound 3: 1.1-fold (0.04 log units) below, and the stated range covers the measured number.
By their numbers in this assay, from the lowest: compound 2; then compounds 3 and 1 (each within the scatter of the next).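

In this assay the move to 2-ethoxypyridin-3-yl gives a 2.1-fold higher number from compound 2 to compound 3 (0.33 log units; beyond the scatter) and so does not keep the lower number of compound 2. Against 2-methoxyphenyl the same group gives a 1.3-fold lower number from compound 1 to compound 3 (0.13 log units; within the scatter) and thus shows that a pyridine ring bearing ethoxy at this place stays level with the phenyl ring bearing methoxy.

Whether the nitrile alone accounts for the lower number of compound 2 stays open, as does the effect of an amine or a longer alkoxy chain on this ring. No measurement at hand explains these steps.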